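The compounds below may be only part of what the source reports. "The series", "measured", "known", "first", "only" and "open" are said of these compounds alone.

Working notes on the series. Compound 1 `CC(C)=CCC1=C(OCc2cn(-c3ccccc3)nn2)C(=O)c2ccccc2C1=O` carries a plain phenyl on the triazole nitrogen; in an ADME assay on HepG2 cells (Homo sapiens) for cytotoxicity, read by MTT assay, with a stated time of 24 h (a higher number here means that more compound is tolerated, a lower number that less compound is tolerated), compound 1 gives 100000 nM. Compound 2 `CC(C)=CCC1=C(OCc2cn(-c3ccc([N+](=O)[O-])cc3)nn2)C(=O)c2ccccc2C1=O` bears a 4-nitrophenyl in that position, and in this assay compound 2 gives 540000 nM. Compound 3 `COc1ccc(-n2cc(COC3=C(CC=C(C)C)C(=O)c4ccccc4C3=O)nn2)c([N+](=O)[O-])c1` bears a 4-methoxy-2-nitrophenyl, and in this assay compound 3 gives 532000 nM. The cores of compound 2 and compound 3 differ as 4-methoxy-2-nitrophenyl in place of 4-nitrophenyl on an aromatic nitrogen; the step is a 1.0-fold lower number from compound 2 to compound 3 (0.01 log units; within the scatter), so the two sit together. Taking the nitro away, (hydrogen in place of nitro on an aromatic carbon), gave a 5.4-fold lower number from compound 2 to compound 1 (0.73 log units; beyond the scatter). The remaining step, a 5.3-fold higher number from compound 1 to compound 3 (0.73 log units; beyond the scatter), runs the other way.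

Compound 4 `COc1ccc(-n2cc(COC3=C(CC=C(C)C)C(=O)c4ccccc4C3=O)nn2)cc1` is the nitro-free partner of compound 3: hydrogen in place of nitro on an aromatic carbon. This is the same kind of change as from compound 2 to compound 1, not the same one: there the hydrogen enters para to a large group, here ortho to a large group and meta to a methoxy group. The expectation for compound 4 rests on the earlier step of a 5.4-fold lower number from compound 2 to compound 1 (0.73 log units; beyond the scatter), and a step of like size, a 4.4-fold lower number from compound 3 to compound 4 (0.65 log units; beyond the scatter), is expected; the differing surroundings of the place keep the range wide. Compound 4 is therefore estimated at 120000 nM, expected to fall between 50000 nM and 350000 nM.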

Compound 4, half-maximal cytotoxic concentration: 200000 nM
The estimate for compound 4 lay 1.7-fold (0.22 log units) below the measured number; low and high end bracket the measured number.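

Hydrogen in place of nitro gives a lower number on both cores in this assay, and the two steps do not differ: the same change on two cores in this assay, a 5.4-fold lower number (0.73 log units; beyond the scatter) from compound 2 to compound 1 and a 2.7-fold lower number (0.42 log units; beyond the scatter) from compound 3 to compound 4, 2.0-fold (0.31 log units) apart, within the scatter of two such steps. The change therefore carries in direction and, within the scatter, in size between these two cores, the new step being a 2.7-fold lower number from compound 3 to compound 4 (0.42 log units; beyond the scatter); methoxy in place of nitro gives a 2.7-fold lower number from compound 2 to compound 4 (0.43 log units; beyond the scatter), and methoxy in place of hydrogen gives a 2.0-fold higher number from compound 1 to compound 4 (0.30 log units; within the scatter), so compound 1 and compound 4 sit together. This rests on two pairs only, both with high numbers in a single assay, and does not show that the step would hold on a core outside these compounds or for a nitro in any other place on the ring.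

On these data alone, whether an amine or a carboxylic acid in the place of the nitro would follow the nitro or the hydrogen remains open. Also open, as far as these compounds go, is what a halogen such as chlorine would give in that place.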